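Methyl-to-hydrogen on the pyrrole nitrogen: a repeated step

A few compounds are considered here, and "the series" means these few. Any claim that something is new, unique, unknown or untested is made for them only; others in the source may bear on it.

Compound 1 `O=c1cc(-c2cc(Br)c(Br)[nH]2)oc2ccccc12` — 1280 nM
Compound 2 `Cn1c(-c2cc(=O)c3ccccc3o2)cc(Br)c1Br` — 670 nM
Compound 3 `Cn1c(-c2cc(-c3ccc[nH]3)no2)cc(Br)c1Br` — 3100 nM

All three were tested in a functional assay on KB403 cells (Homo sapiens) for cytotoxicity, read by MTT assay, with stated times of 6 h and 48 h; a higher number here means a weaker inhibitor, a lower number a stronger inhibitor. Compound 2 and compound 1 differ in one place, (hydrogen in place of methyl on an aromatic nitrogen), and this change gave a 1.9-fold higher number from compound 2 to compound 1 (0.28 log units; within the scatter). Compound 3 carries a different core from compound 2, and the difference between the two cores is not broken down here; in this assay compound 3 gives 3100 nM, the highest of the three numbers, beyond the scatter from both compound 1 and compound 2.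

Compound 4 `Brc1cc(-c2cc(-c3ccc[nH]3)no2)[nH]c1Br` has not yet been measured. It differs from compound 3 by hydrogen in place of methyl on an aromatic nitrogen, the same change, at the same place, that separates compound 2 from compound 1. Because that earlier change gave a 1.9-fold higher number from compound 2 to compound 1 (0.28 log units; within the scatter), compound 4 is expected to show a step of about a 1.8-fold higher number from compound 3 to compound 4 (0.25 log units; within the scatter), similar in size and direction. Resting on that single precedent, compound 4 is estimated at 5500 nM, with a likely range from 2500 nM to 12000 nM.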

Compound 4, half-maximal inhibitory concentration: 4820 nM
Estimate against measurement, compound 4: 1.1-fold (0.06 log units) above, and the stated range covers the measured number.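

In this assay, hydrogen in place of methyl on the aromatic nitrogen gave a 1.6-fold higher number from compound 3 to compound 4 (0.19 log units; within the scatter), and set beside the earlier case, the change carries from one core to the other with no difference that can be told apart: the same change on two cores in this assay, a 1.9-fold higher number (0.28 log units; within the scatter) from compound 2 to compound 1 and a 1.6-fold higher number (0.19 log units; within the scatter) from compound 3 to compound 4, 1.2-fold (0.09 log units) apart, within the scatter of two such steps

Both steps lie within the scatter. Neither pair shows a clear difference between the compound with the methyl and the compound with hydrogen in this cytotoxicity read-out. Going by these compounds alone, they do not establish that the methyl is without consequence, and with only two cores they say nothing about how the change would behave on any further core.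

The compounds shown leave open what a longer chain on that nitrogen, such as an ethyl group or a chain ending in an amine, would do to the number. They also leave open whether a chloro group or a carboxylic acid in place of a bromo group would alter the picture on either core.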